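The source may report more compounds than this note shows. Statements on the series, on what has been measured and on what is new or still open speak of the compounds shown alone.

Compound 1 `COc1cc(OC)cc(-c2ccc3c(c2)C(CC(=O)OCC2CO2)C(C(=O)OCC2CO2)=C(N)O3)c1` reaches only the limit of > 80000 nM in a functional assay on HL-60 cells (Homo sapiens) for cytotoxicity, read by CellTiter-Blue, with a stated time of 48 h; on this read-out higher numbers stand for weaker inhibition and lower numbers for stronger inhibition (the limit of > 80000 nM in this assay, at which 1 of the 3 values shown sits). Compound 2 `CCOC(=O)CC1C(C(=O)OCC)=C(N)Oc2ccc(-c3ccc(F)cc3)cc21` gives 72100 nM in this assay, the higher of the two actual numbers recorded, while compound 3 `C#CCOC(=O)CC1C(C(=O)OCC#C)=C(N)Oc2ccc(-c3cccc(NC(=O)CCl)c3)cc21` gives 5300 nM, a gap that lies beyond the usual scatter. Among the measured compounds shown here, no pair of measured compounds differs in just one place, so no single step is available to calibrate a change on the pendant aryl ring.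

Compound 4 `CCOC(=O)CC1C(C(=O)OCC)=C(N)Oc2ccc(-c3cccc(C(N)=O)c3)cc21` has not yet been measured; it differs from compound 2 in one place: 3-carbamoylphenyl in place of 4-fluorophenyl on an aromatic carbon. The step from compound 2 to compound 4 is expected to be modest and downward, a 1.6-fold lower number from compound 2 to compound 4 (0.20 log units; within the scatter), and it may well fall within the scatter. Compound 4 is therefore estimated at 45000 nM, within a range from 15000 nM to 80000 nM.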

Compound 4, half-maximal inhibitory concentration: 5400 nM
Beside the measured number, compound 4's estimate is 8.3-fold (0.92 log units) above it; measured number outside the range, below it.
By their numbers in this assay, from the lowest: compounds 3 and 4 (each within the scatter of the next); then compound 2. At a limit, above all of these: compound 1.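

In this assay the pendant aryl ring now has a calibrated single-place step: 3-carbamoylphenyl in place of 4-fluorophenyl on an aromatic carbon gives a 13-fold lower number from compound 2 to compound 4 (1.13 log units; beyond the scatter) and is large. The number at this position therefore depends strongly on the group it carries, with the rest of the structure unchanged. Nothing measured here accounts for the size of this step.

The step changes the group and its place on the pendant ring together, so the two effects remain unseparated. As far as these compounds go, whether an amine or a carboxylic acid in place of the carbamoyl group would hold this number stays open.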